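Swapping an Open Amine Chain for a Closed Ring

The compounds below may be only part of what the source reports. "The series", "measured", "known", "first", "only" and "open" are said of these compounds alone.

Compound 1 `COc1ccc(CN2CCC(C(=O)Nc3ccc(CNc4nc(N(C)C)nc5cc(C)ccc45)cc3)CC2)cc1`: in a functional assay on SV5A8 cells (Homo sapiens) for cytotoxicity (a lower number here means a stronger inhibitor, a higher number a weaker inhibitor), compound 1 reaches only the limit > 6180 nM.
Compound 2 `Cc1ccc2c(NCc3ccc(NC(=O)C4CCN(Cc5ncc[nH]5)CC4)cc3)nc(N(C)C)nc2c1`: in this assay compound 2 reaches only the limit > 20000 nM.
Compound 3 `Cc1ccc2c(NCc3ccc(NC(=O)C4CCN(Cc5ccccc5)CC4)cc3)nc(N(C)CCN(C)C)nc2c1`: in this assay compound 3 reaches only the limit > 8830 nM.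

Compound 3 thus stands among three results that are all limits, none a number. Among the measured compounds shown here, the single one-place step, a step that the two limits leave unreadable from compound 1 to compound 2, is unreadable for the same reason (the limit of > 20000 nM in this assay, at which 1 of the 3 values shown sits, (the limit of > 6180 nM in this assay, at which 1 of the 3 values shown sits), (the limit of > 8830 nM in this assay, at which 1 of the 3 values shown sits)). Compound 4 `Cc1ccc2c(NCc3ccc(NC(=O)C4CCN(Cc5ccccc5)CC4)cc3)nc(N3CCN(C)CC3)nc2c1` differs from compound 3 by 4-methylpiperazin-1-yl in place of (2-(dimethylamino)ethyl)(methyl)amino on an aromatic carbon. For the measured compounds named here, no measured step touches this change, and no value is a number. The expected step is a step that the limit leaves unreadable from compound 3 to compound 4, nothing beyond the scatter. Compound 4 is therefore expected near 15000 nM, within 5000 nM to 40000 nM, and most probably reported once more as a limit.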

Compound 4, half-maximal inhibitory concentration: > 17700 nM
Compound 4: a limit, no number (the forecaster's own chance of this, stated with the estimate: 80%); at least 1.1-fold (0.07 log units) between middle value and limit.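

Compound 3 and compound 4 are both reported in this assay only as limits, not numbers, so no step can be read between them. The compounds shown leave open what actual concentration any of them would need to inhibit.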